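The compounds below may be only part of what the source reports. "The series", "measured", "known", "first", "only" and "open" are said of these compounds alone.

Of the compounds shown here, three have been measured in a functional assay (Cavia porcellus) with sulfonylurea receptors; K-ATP channels (Homo sapiens) as the target; a lower number here means a stronger inhibitor, a higher number a weaker inhibitor. Compound 1 `CC(O)(C(=O)Nc1ccc(S(=O)(=O)c2ccccc2)c(F)c1)C(F)(F)F` gives 1800 nM in this assay. Compound 2 `CC(O)(C(=O)Nc1ccc(S(=O)(=O)c2ccccc2)c(C#N)c1)C(F)(F)F` differs from compound 1 in one place: cyano in place of fluoro on an aromatic carbon. In this assay compound 2 gives 3800 nM, and the change made a 2.1-fold higher number from compound 1 to compound 2 (0.32 log units; beyond the scatter). Compound 3 `CC(O)(C(=O)Nc1ccc(C(=O)c2ccccc2)cc1F)C(F)(F)F` rests on a different core, and how its core differs from the core of compound 1 is not broken down here. In this assay compound 3 gives 11000 nM, the highest of the three numbers. Compound 4 `CC(O)(C(=O)Nc1ccc(C(=O)c2ccccc2)cc1C#N)C(F)(F)F` has not yet been measured. It differs from compound 3 by the same kind of change: cyano in place of fluoro on an aromatic carbon. The surroundings of the place are not the same word for word: in compound 1 the fluoro sits ortho to a group of 9 heavy atoms and meta to a large group, while in compound 3 it sits ortho to a large group and meta to a benzoyl group (8 heavy atoms). Among the measured compounds shown here, the earlier step is the only guide, so a step of similar size is expected from compound 3 to compound 4, a 2.0-fold higher number from compound 3 to compound 4 (0.30 log units; within the scatter). On that basis compound 4 is estimated at 22000 nM in this assay, expected to lie between 9000 nM and 55000 nM.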

Compound 4, half-maximal inhibitory concentration: 3800 nM
Compound 4: the middle estimate sits 5.8-fold (0.76 log units) above what was measured; measured number outside the range, below it.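

In this assay, putting cyano in place of fluoro on the core of compound 3 gives a 2.9-fold lower number from compound 3 to compound 4 (0.46 log units; beyond the scatter), so here the swap improves inhibition, whereas on the core of compound 1 it weakened it. This change therefore does not carry over from one core to the other in this series, not even in its direction: the same change on two cores in this assay, a 2.1-fold higher number (0.32 log units; beyond the scatter) from compound 1 to compound 2 and a 2.9-fold lower number (0.46 log units; beyond the scatter) from compound 3 to compound 4, 6.1-fold (0.79 log units) apart, beyond the scatter of two such steps Two pairs of compounds show only that the outcome depends on the core; they cannot tell which difference between the cores is responsible, nor whether a third core would follow compound 1 or compound 3.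

From the compounds shown here alone, it remains open how other groups at this same place, such as a chloro, a methyl or an amine, would rank against fluoro and cyano on each core. Also open, going by these compounds, is whether the two cores would still part ways if the hydroxyl group on the side chain shared by all four compounds gave way to an amine.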